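The source may report more compounds than this note shows. Statements on the series, on what has been measured and on what is new or still open speak of the compounds shown alone.

Of the compounds shown here, three have been measured in an assay for inhibition of Polyunsaturated fatty acid 5-lipoxygenase (Rattus norvegicus); on this read-out lower numbers stand for stronger inhibition and higher numbers for weaker inhibition. Compound 1 `CCCCC/C=C\C/C=C\C/C=C\C=C\C(S)CCCC(=O)O` gives 7600 nM. Within the data shown here, compound 2 `CCCCC/C=C\C/C=C\C/C=C\C=C\C(N)CCCC(=O)O` carries an amino group in place of the sulfanyl group of compound 1; in this assay compound 2 gives 25000 nM, and the step of a 3.3-fold higher number from compound 1 to compound 2 (0.52 log units; beyond the scatter) is the only single-change comparison among the measured compounds. Compound 3 `CCCCC/C=C\C/C=C\C/C=C\C=C\C(CCCC(=O)O)=N\O` gives 11000 nM; on the numbers shown, compound 3 stands second highest of the three, within the scatter of compound 1 and beyond the scatter of compound 2.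

Compound 4 `CCCCC/C=C\C/C=C\C/C=C\C=C\C(CCCC(=O)O)=N\NC(N)=O` has not yet been measured. It differs from compound 3 by ureido in place of hydroxy on a double-bonded nitrogen. Among the measured compounds shown here, the one measured step, the exchange of sulfanyl for amino on a saturated chain carbon, concerns a different position and different groups, so it offers no direct guide to this change. For the measured compounds named here, with no comparable step to draw on, the expectation in this assay is a change that stays within the usual scatter, in either direction. The estimated value for compound 4 is 11000 nM, with a range from 3000 nM to 40000 nM. That estimate corresponds to an expected step of no change at the digits printed from compound 3 to compound 4 (within the scatter).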

Compound 4, half-maximal inhibitory concentration: 7000 nM
The estimate for compound 4 lay 1.6-fold (0.20 log units) above the measured number; the measured number falls inside the stated range.
By their numbers in this assay, from the lowest: compounds 4, 1 and 3 (each within the scatter of the next); then compound 2.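

In this assay, putting ureido in place of hydroxy on a double-bonded nitrogen gives a 1.6-fold lower number from compound 3 to compound 4 (0.20 log units; within the scatter). Among these compounds, this is the first single change seen at this position, and it shows that a group of 4 heavy atoms can replace one of 1 heavy atom with no difference beyond the usual scatter, whereas the only earlier step, at a saturated chain carbon, went beyond it. No measurement on hand explains this result.

One step cannot show how far this holds: a methoxy group, a phenyl group or a longer chain on the same nitrogen could still shift the number beyond the scatter. On these data alone, it also remains open whether any group at this position can bring the number clearly below that of compound 3.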